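Swapping the ester for a piperidine amide in a chromene series

This account rests on a few compounds, and the source may have more. Where it says the series, first, only, none or still open, it means among the compounds named here.

Compound 1 `CCOC(=O)C1=Cc2ccc(OC)cc2OC1c1cc(OC)c(OC)c(OC)c1` gives 25000 nM in a functional assay for inhibition of nuclear factor NF-kappa-B complex (Homo sapiens) (a lower number here means a stronger inhibitor, a higher number a weaker inhibitor), the highest of the two numbers available. Compound 3 `COC(=O)C1=Cc2ccc(OC)cc2OC1c1cc(OC)c(OC)c(OC)c1` gives 13800 nM, and the step of a 1.8-fold lower number from compound 1 to compound 3 (0.26 log units; within the scatter) is within the scatter. Compound 2 `CNC(=O)C1=Cc2ccc(OC)cc2OC1c1cc(OC)c(OC)c(OC)c1` reached only a limit, > 50000 nM. Compound 4 `COc1ccc2c(c1)OC(c1cc(OC)c(OC)c(OC)c1)C(C(=O)N1CCCCC1)=C2` differs from compound 1 as follows: piperidin-1-yl in place of ethoxy on a carbonyl carbon. The two steps that bear on it both involve amides. The step of an at least 2.0-fold higher number from compound 1 to compound 2 (0.30 log units; that floor lies within the scatter) weakened, and an at least 3.6-fold lower number from compound 2 to compound 3 (0.55 log units; beyond the scatter) shows the ester outperforming the amide. A weaker result is therefore expected from another amide. Compound 4 is expected near 45000 nM, between 15000 nM and 150000 nM. For compound 4 this estimate means a 1.8-fold higher number from compound 1 to compound 4 (0.26 log units; within the scatter).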

Compound 4, half-maximal inhibitory concentration: > 50000 nM
Compound 4 ended at the assay's limit (the forecaster's own chance of this, stated with the estimate: 45%); at least 1.1-fold (0.04 log units) between middle value and limit.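

On this carbonyl carbon, piperidin-1-yl gives an at least 3.6-fold higher number from compound 3 to compound 4 (0.55 log units; beyond the scatter), while the comparison with the ethyl ester gives an at least 2.0-fold higher number from compound 1 to compound 4 (0.30 log units; that floor lies within the scatter). So an amide with a ring and no amide hydrogen, unlike the methylamino amide of compound 2, also falls clearly short of the methyl ester. The step between the two amides cannot be read: the limit of > 50000 nM in this assay, at which 2 of the 4 values shown sit.

Which of the two amides is weaker stays open, as does how far either lies beyond the limit. Also open, as far as these compounds go, is how a carboxylic acid or a longer chain such as a butyl ester would behave on this carbonyl carbon.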